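The source may report more compounds than this note shows. Statements on the series, on what has been measured and on what is new or still open speak of the compounds shown alone.

Measured so far, in a functional assay on HL-60 cells (Homo sapiens) for cytotoxicity, read by WST assay, with a stated time of 48 h; a higher number here means a weaker inhibitor, a lower number a stronger inhibitor:

- compound 1, `COC[C@H](C)[C@@H](C)C(c1ccc(O)c(OC)c1)c1ccc(O)c(OC)c1`: compound 1 gives 68000 nM
- compound 2, `COc1cc(C(c2ccc(O)c(OC)c2)[C@H](CC(C)C)C(C)C)ccc1O`: compound 2 gives 9600 nM
- compound 3, `COc1cc(C(c2ccc(O)c(OC)c2)[C@H](CO)C(C)C)ccc1O`: compound 3 gives > 100000 nM

The value of compound 3 in this assay is a limit, not a number; only a floor is known for it. Compound 3 sits at the limit of > 100000 nM in this assay, at which 1 of the 3 values shown sits, alone among the three.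

The step in question leads to compound 4, `COc1cc(C(c2ccc(O)c(OC)c2)[C@H](C)[C@@H](C)CO)ccc1O`, an isomer of compound 3: 2-(hydroxymethyl)-1-methylpropyl in place of 1-(hydroxymethyl)-2-methylpropyl on a saturated chain carbon bound to two aromatic carbons. For the measured compounds named here, three measured steps bear on it. Compound 1, carrying 2-(methoxymethyl)-1-methylpropyl on the same saturated chain carbon, gave an at least 1.4-fold higher number from compound 1 to compound 3 (0.16 log units; that floor lies within the scatter), so moving a single-oxygen group along the chain, with a hydroxy in place of a methoxy, changed little. Going by the values given here, the only step beyond the scatter at that position was a 7.1-fold lower number from compound 1 to compound 2 (0.85 log units; beyond the scatter), and an at least 10-fold higher number from compound 2 to compound 3 (1.01 log units; beyond the scatter) runs the other way, so the oxygen-bearing chains of compounds 1 and 3 both sit far from compound 2.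

Compound 4 keeps a hydroxy on the chain and is therefore expected to remain in the weak region of compounds 1 and 3, with a fair chance of again reporting only a limit. Compound 4 is expected to give about 110000 nM, in the range 50000 nM to 300000 nM. The expected step that the limit leaves unreadable from compound 3 to compound 4 is within the scatter.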

Compound 4, half-maximal inhibitory concentration: > 100000 nM
Compound 4: no number, only a limit; the forecaster's own chance of this, stated with the estimate: 55%; the middle value does not contradict the limit.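

In this assay compound 4 gives > 100000 nM as a limit and not as a number. On the saturated chain carbon bound to two aromatic carbons, 2-(hydroxymethyl)-1-methylpropyl gives an at least 10-fold higher number from compound 2 to compound 4 (1.01 log units; beyond the scatter) against 1-isopropyl-3-methylbutyl, so a second hydroxy-bearing isomer stands well apart from the oxygen-free chain, while an at least 1.4-fold higher number from compound 1 to compound 4 (0.16 log units; that floor lies within the scatter) leaves hydrogen in place of methyl on that oxygen with no step shown beyond the scatter. The step between the isomers compound 3 and compound 4 cannot be read, so the placing of the hydroxy along the chain yields no order, and the oxygen-bearing chains now collect at a single limit: the limit of > 100000 nM in this assay, at which 2 of the 4 values shown sit.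

As far as these compounds go, how far compound 3 and compound 4 lie past that limit stays open, and with it any difference between the two isomers. Also open, from the compounds shown here alone, is whether an amine in place of the hydroxy, or a longer carbon chain than 1-isopropyl-3-methylbutyl, would keep the number close to that of compound 2 at 9600 nM or move it further down in this assay.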